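The source may hold more compounds than are shown below. What is called first, only, known or untested is meant among the compounds shown, and "the series" means these compounds.

Compound 1 `CCC(C)(C)Cc1c[nH]c(CCc2ccc(-c3cccc(C)n3)cc2)n1` gives 19 nM in a functional assay on HEK293 cells for agonist activity at Bombesin receptor subtype-3 (Mus musculus), read by luminescence and calcium flux, with a stated time of 10 min; on this read-out lower numbers stand for an effect already at smaller amounts and higher numbers for an effect only at larger amounts of compound. Compound 2 `CCC(C)(C)Cc1c[nH]c(CCc2ccc(-c3ccc(F)cn3)cc2)n1` gives 16 nM in this assay.

Compound 2 holds the lower of the two numbers, yet the step of a 1.2-fold lower number from compound 1 to compound 2 (0.07 log units; within the scatter) lies within the scatter, so the two cannot be told apart. Compound 3 `CCC(C)(C)Cc1c[nH]c(CCc2ccc(-c3ccns3)cc2)n1` differs from compound 2 by 1,2-thiazol-5-yl in place of 5-fluoropyridin-2-yl on an aromatic carbon. Among the compounds with values here, the only related step, an exchange of one aryl group for another, stayed within the scatter, so for compound 3 a small step of a 1.6-fold higher number from compound 2 to compound 3 (0.19 log units; within the scatter) is expected, if anything toward higher numbers. Compound 3 is estimated at 25 nM, with a range from 8 nM to 80 nM.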

Compound 3, half-maximal effective concentration: 3.1 nM
For compound 3 the middle estimate is 8.1-fold (0.91 log units) above the measured one, outside the stated range (below it).
By their numbers in this assay, from the lowest: compound 3; then compounds 2 and 1 (each within the scatter of the next).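

Exchanging one six-membered aromatic ring for another left the number within the scatter, but the five-membered 1,2-thiazol-5-yl ring on this aromatic carbon, para to a large group, gives a 5.2-fold lower number from compound 2 to compound 3 (0.71 log units; beyond the scatter) in this assay and a 6.1-fold lower number from compound 1 to compound 3 (0.79 log units; beyond the scatter). This position therefore responds to the choice of ring, although that rests on a single five-membered example. Nothing available explains the change. As far as these compounds go, it remains open whether a furan or thiophene ring would behave in the same way. From the compounds shown here alone, the effect of an amine or a carboxylic acid on this ring is also open.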